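The compounds below may be only part of what the source reports. "The series", "measured", "known", "first", "only" and "open" are said of these compounds alone.

Working notes on the series. Compound 1 `C#Cc1cn([C@@H]2O[C@H](CO)[C@@H](O)[C@H]2O)c2ncnc(C)c12` gives 160 nM in a functional assay on CEM-DNR-bulk cells (Homo sapiens), read by MTT assay, with a stated time of 72 h (on this read-out higher numbers stand for weaker inhibition and lower numbers for stronger inhibition), the lowest of the two numbers in hand. Among the measured compounds shown here, its nearest neighbour is compound 2 `C#Cc1cn([C@@H]2O[C@H](CO)[C@@H](O)[C@H]2O)c2ncnc(N(C)C)c12`, which in this assay gives 240 nM; the only measured step, a 1.5-fold higher number from compound 1 to compound 2 (0.18 log units; within the scatter), concerns the dimethylamino in place of methyl on an aromatic carbon and stays within the scatter. Compound 3 `O=c1[nH]cnc2c1c(-c1ccsc1)cn2[C@@H]1O[C@H](CO)[C@@H](O)[C@H]1O` carries a thiophen-3-yl group on a different core, and in this assay compound 3 reaches only > 20000 nM, a limit of the assay and not a number. Of the three values, one is the limit of > 20000 nM in this assay, at which 1 of the 3 values shown sits.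

Compound 4 `Cc1ncnc2c1c(-c1ccoc1)cn2[C@@H]1O[C@H](CO)[C@@H](O)[C@H]1O` differs from compound 1 by furan-3-yl in place of ethynyl on an aromatic carbon. For the measured compounds named here, no measured step touches this position, so the step from compound 1 to compound 2 gives no direct guide, and compound 3 shows a five-membered aryl at the same place only together with another core, without a step to compound 1. A weaker number is expected for compound 4, the estimated step being a 3.8-fold higher number from compound 1 to compound 4 (0.57 log units; beyond the scatter). The estimate for compound 4 in this assay is 600 nM, with a range of 150 nM to 5000 nM.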

Compound 4, half-maximal inhibitory concentration: > 20000 nM
Compound 4 ended at the assay's limit; the forecaster's own chance of this, stated with the estimate: 15%; middle value at least 33-fold (1.52 log units) away from the limit.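

Furan-3-yl in place of ethynyl is the first measured change at this position, and in this assay it gives an at least 120-fold higher number from compound 1 to compound 4 (2.09 log units; beyond the scatter), so this aromatic carbon does not tolerate every replacement on the core of compound 1. Compound 4 gives > 20000 nM, which is a limit of the assay and not a number, so the true size of the step cannot be read. Compound 4 now sits at the same limit as compound 3, which carries a different core: the limit of > 20000 nM in this assay, at which 2 of the 4 values shown sit.

Going by these compounds, it remains open whether the loss belongs to the furan-3-yl ring in particular or to removing the ethynyl group in general. On these data alone, a nitrile or a longer alkynyl chain on this carbon would bear on that question, and how such groups behave on this core remains unknown.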